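The compounds below may be only part of what the source reports. "The series", "measured", "known", "first", "only" and "open" are said of these compounds alone.

Of the compounds shown here, three of this hydrazide series have been tested in a functional assay on Bel-7402 cells (Homo sapiens) for inhibition, read by sulforhodamine B assay, with a stated time of 48 h, tested at 10 uM; a lower number here means less inhibition of growth, a higher number more inhibition of growth at the concentration tested. Compound 3 `O=C(N/N=C/c1ccccc1O)c1ccc(-c2ccc(F)cc2F)o1` gives 91.8%, compound 2 `O=C(N/N=C/c1ccc(-c2ccc(F)cc2F)o1)c1ccccc1O` gives 63.4%, and compound 1 `O=C(N/N=C/c1ccccc1O)c1ccc(-c2ccc(F)cc2)o1` gives 40%. Compound 3 and compound 1 differ in one place, (hydrogen in place of fluoro on an aromatic carbon), and the step is a number 51.8 percentage points lower from compound 3 to compound 1 (beyond the scatter). Compound 2 and compound 3 have the same atoms joined differently; the difference between the two cores is not broken down here. Compound 2 stands between compound 1 and compound 3, beyond the scatter from each.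

Compound 4 `O=C(N/N=C/c1ccc(-c2ccc(F)cc2)o1)c1ccccc1O` has not yet been measured. It differs from compound 2 by hydrogen in place of fluoro on an aromatic carbon, the same change that turns compound 3 into compound 1, at a place described in the same words. On the core of compound 3 that change produced a large drop, a number 51.8 percentage points lower from compound 3 to compound 1 (beyond the scatter). Within the data shown here, whether it acts as strongly on the core of compound 2 is not known, as each core has only one measured pair. A step of a number 33.4 percentage points lower from compound 2 to compound 4 (beyond the scatter) is expected, smaller than the measured one because compound 2 gives 63.4% and so leaves less room to fall. Compound 4 is estimated at 30%, between 5% and 60%.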

Compound 4, percent growth inhibition at one concentration: 81.6%
Beside the measured number, compound 4's estimate is 51.6 percentage points below it, and the stated range ends below it.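

On one core, the change from 2,4-difluorophenyl to 4-fluorophenyl gives a number 18.2 percentage points higher from compound 2 to compound 4 (beyond the scatter) in this assay. The same change therefore does not carry over from one core to the other in these four compounds, in either direction or size: the same change on two cores in this assay, a number 51.8 percentage points lower (beyond the scatter) from compound 3 to compound 1 and a number 18.2 percentage points higher (beyond the scatter) from compound 2 to compound 4, 70 percentage points apart, beyond the scatter of two such steps. This shows that a step read on one of these two cores is no guide to the other, but with a single measured pair per core it does not show how general the difference is, what lies behind it, or whether it would hold in any other assay.

The compounds shown leave open whether other groups at the place of the fluoro that leaves, such as chloro, methoxy or an amine, would also behave differently on the two cores. Also open, on these data alone, is what happens on each core if the remaining fluoro of the 4-fluorophenyl group gives way to a hydrogen or a carboxylic acid.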